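Swapping the Aryl Group on the Amide Nitrogen

The compounds below may be only part of what the source reports. "The series", "measured", "known", "first", "only" and "open" are said of these compounds alone.

Measured compounds:
compound 1, `CO[C@@H]1CC=C2NN(c3ccc(C)cc3)C(=O)C[C@]2(C)O1`, gives 28700 nM in a functional assay on HCT-116 cells (Homo sapiens) for inhibition, read by sulforhodamine B assay, with a stated time of 48 h; on this read-out higher numbers stand for weaker inhibition and lower numbers for stronger inhibition
compound 2, `CO[C@@H]1CC=C2NN(c3cncnc3)C(=O)C[C@]2(c2ccccc2)O1`, gives 9130 nM in this assay
compound 3, `CO[C@@H]1CC=C2NN(c3ccc(Cl)cc3)C(=O)C[C@]2(C)O1`, gives 35700 nM in this assay

Compound 3 carries the highest of the three numbers in this assay, with compound 1 sitting close enough that the two are within the scatter; compound 2 lies clearly below both. Among the compounds with values here, the only single-point step measured so far is a 1.2-fold higher number from compound 1 to compound 3 (0.09 log units; within the scatter), and it does not touch the part of the molecule that changes next.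

Compound 4, `CO[C@@H]1CC=C2NN(c3cncnc3)C(=O)C[C@]2(C)O1`, arises from compound 3 by the change (pyrimidin-5-yl in place of 4-chlorophenyl on an amide-type nitrogen in a ring). Within the data shown here, no measured pair isolates this change: compound 2 also carries the pyrimidin-5-yl group, but it differs from compound 4 at the methyl-bearing ring atom as well, so its value cannot be assigned to either change alone. The expectation for compound 4 therefore rests on the values of compound 3 and compound 2 as bounds rather than on a measured step. Compound 4 is estimated at 22000 nM, within 9000 nM to 55000 nM, which means an expected step of a 1.6-fold lower number from compound 3 to compound 4 (0.21 log units; within the scatter).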

Compound 4, half-maximal inhibitory concentration: 15100 nM
Estimate against measurement, compound 4: 1.5-fold (0.16 log units) above, within the range that was stated.
By their numbers in this assay, from the lowest: compounds 2, 4, 1 and 3 (each within the scatter of the next, the first and the last beyond it).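

In this assay, within the data shown here, the pyrimidin-5-yl group on the amide-type nitrogen gives the first step beyond the scatter at this position (a 2.4-fold lower number from compound 3 to compound 4 (0.37 log units; beyond the scatter)), though a modest one, and only against the 4-chlorophenyl group, since the same exchange against the 4-methylphenyl group stays within the scatter (a 1.9-fold lower number from compound 1 to compound 4 (0.28 log units; within the scatter)). With the pyrimidin-5-yl group held fixed, methyl in place of phenyl on the saturated ring carbon also stays within the scatter (a 1.7-fold higher number from compound 2 to compound 4 (0.22 log units; within the scatter)), so that pair shows no clear effect of this exchange. Nothing available here accounts for the step at the nitrogen.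

The compounds shown leave open how an unsubstituted phenyl, a pyridine ring, or an aryl ring bearing an amine or a carboxylic acid would read on this nitrogen. They also leave open whether any group at this position can move the number much further than these modest steps.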